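The compounds below may be only part of what the source reports. "The series", "measured", "known", "first", "only" and "open" are said of these compounds alone.

Measured in a functional assay on CCRF-CEM cells (Homo sapiens) for inhibition, read by MTT assay, with a stated time of 72 h; a higher number here means a weaker inhibitor, a lower number a stronger inhibitor:
- compound 1 `COc1cc(NC(C)CCCNC(=O)NNC(=O)Nc2ccc(Br)cc2)c2ncccc2c1`: 110000 nM
- compound 2 `COc1cc(NC(C)CCCNC(=O)Nc2ccc(Cl)cc2)c2ncccc2c1`: 24000 nM

Of these two compounds, compound 2 has the lower number, 24000 nM, and so is the stronger inhibitor in this assay. The next compound to be tested is compound 3 `COc1cc(NC(C)CCCNC(=O)NNC(=O)Nc2ccc(O)cc2)c2ncccc2c1`. Moving to it from compound 2 places ((4-hydroxyphenyl)carbamoyl)amino in place of 4-chlorophenyl on an amide-type nitrogen.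

Among the measured compounds shown here, only one measured step bears on this change. It runs the opposite way, with 4-chlorophenyl replacing ((4-bromophenyl)carbamoyl)amino at the same place: a 4.6-fold lower number from compound 1 to compound 2 (0.66 log units; beyond the scatter). For the measured compounds named here, compound 3 shares the carbamoylamino form of compound 1, but carries 4-hydroxyphenyl where compound 1 has 4-bromophenyl, and no measured step shows what that exchange does. The reverse of the measured step is therefore only a rough guide, and a modest rise in the number is expected rather than a large one. The expected change is a 3.3-fold higher number from compound 2 to compound 3 (0.52 log units; beyond the scatter). Compound 3 is estimated at 80000 nM, with an expected range of 25000 nM to 200000 nM.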

Compound 3, half-maximal inhibitory concentration: 111000 nM
For compound 3 the middle estimate is 1.4-fold (0.14 log units) below the measured one; low and high end bracket the measured number.
By their numbers in this assay, from the lowest: compound 2; then compounds 1 and 3 (each within the scatter of the next).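

With hydroxy in place of bromo on an aromatic carbon, this assay shows a 1.0-fold higher number from compound 1 to compound 3 (0.00 log units; within the scatter) and so gives no sign of a difference between these two groups in the carbamoylamino form. Placing ((4-hydroxyphenyl)carbamoyl)amino in place of 4-chlorophenyl on the amide-type nitrogen gives a 4.6-fold higher number from compound 2 to compound 3 (0.67 log units; beyond the scatter) and so adds a second step close in size to the one seen earlier with the bromo compound, a 4.6-fold lower number from compound 1 to compound 2 (0.66 log units; beyond the scatter) in the opposite direction, which means that in these three compounds the higher numbers go with the carbamoylamino form, whichever of the two aromatic groups it carries. Nothing measured here gives a reason for either result.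

From the compounds shown here alone, only bromo and hydroxy are compared at the aromatic carbon of the carbamoylamino form, so it remains open whether an amine or a carboxylic acid there would read the same. Also open, going by these compounds, is how 4-hydroxyphenyl would read when placed directly on the amide-type nitrogen, which would separate the effect of the aromatic group from that of the carbamoylamino form.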